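Ester for chloride on the benzyl ether of compound 1

This account rests on a few compounds, and the source may have more. Where it says the series, first, only, none or still open, it means among the compounds named here.

Of the compounds shown here, three of a shared core have been measured in a functional assay on SK-OV-3 cells (Homo sapiens) for inhibition, read by CCK-8 assay, with a stated time of 70 h; on this read-out higher numbers stand for weaker inhibition and lower numbers for stronger inhibition. Compound 1 `Clc1ccc(COc2ccc(OCCOCCNC3CCCC3)cc2)cc1` gives 7670 nM, the lowest of the three numbers. Compound 3 `CC(C)(C)OC(=O)n1ccc(NCCOCCOc2ccc(OCc3ccccc3)cc2)c1` gives 13000 nM, which lies within the scatter of compound 1. Compound 2 `c1ccc(COc2ccc(OCCOCCNC3CCOC3)cc2)cc1` gives 48000 nM, a number beyond the scatter of compound 1. Compound 4 `COC(=O)c1cccc(COc2ccc(OCCOCCNC3CCCC3)cc2)c1` has not yet been measured in this assay. It differs from compound 1 in one place: 3-(methoxycarbonyl)phenyl in place of 4-chlorophenyl on a saturated chain carbon bound to an oxygen on an aromatic ring. Among the compounds with values here, no pair of measured compounds shows this change, so its size is unknown. The step from compound 1 to compound 4 is expected to be small, at most a modest loss, giving a 1.4-fold higher number from compound 1 to compound 4 (0.16 log units; within the scatter). In this assay compound 4 is therefore estimated at 11000 nM, within a range from 3500 nM to 35000 nM.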

Compound 4, half-maximal inhibitory concentration: 45500 nM
The estimate for compound 4 lay 4.1-fold (0.62 log units) below the measured number; the measured number lies above the stated range.
By their numbers in this assay, from the lowest: compounds 1 and 3 (each within the scatter of the next); then compounds 4 and 2 (each within the scatter of the next).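

At this position, on a saturated chain carbon bound to an oxygen on an aromatic ring, the change is not tolerated silently in this assay: 3-(methoxycarbonyl)phenyl in place of 4-chlorophenyl gives a 5.9-fold higher number from compound 1 to compound 4 (0.77 log units; beyond the scatter) and thus a step beyond the scatter. Within the data shown here, this is the first size seen for any change at this position. Nothing at hand bears on the reason for this step. The group and its ring position changed together, and the compounds shown do not separate the two. A 3-chlorophenyl group, or a carboxylic acid in place of the methyl ester, remains an open case.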